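Replacing the pentyl chain of compound 1 with sec-butyl

The source may hold more compounds than are shown below. What is called first, only, known or untested is meant among the compounds shown, and "the series" means these compounds.

Within the data shown here, in a functional assay on HBL-100 cells (Homo sapiens) for antiproliferative activity, read by sulforhodamine B assay, with a stated time of 48 h (a higher number here means a weaker inhibitor of growth, a lower number a stronger inhibitor of growth), compound 1 (`CCCCCC(C#CC(=O)OC)O/C=C/C(=O)OC`) gives 1900 nM and compound 2 (`CCOC(=O)C#CC(C[C@@H](C)CCC=C(C)C)O/C=C/C(=O)OCC`) gives 2600 nM as the only other measured value. The two lie within the scatter of each other, so compound 1 stands level with compound 2. Compound 3 (`CCC(C)C(C#CC(=O)OC)O/C=C/C(=O)OC`) is not yet measured and differs from compound 1 in one place: sec-butyl in place of pentyl on a saturated chain carbon bound to an oxygen on an unsaturated carbon and a triple-bonded carbon with sec-butyl in place of pentyl on a saturated chain carbon bound to an oxygen on an unsaturated carbon and a triple-bonded carbon. Among the measured compounds shown here, no measured step isolates this change, so no step beyond the scatter is expected in this assay for it. The expected 1.3-fold higher number from compound 1 to compound 3 (0.12 log units; within the scatter) stays within the scatter. For compound 3 the estimated value is 2500 nM with an expected range of 1100 nM to 5500 nM for now.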

Compound 3, concentration for 50% growth inhibition: 340 nM
Beside the measured number, compound 3's estimate is 7.4-fold (0.87 log units) above it, and the stated range ends above it.
By their numbers in this assay, from the lowest: compound 3; then compounds 1 and 2 (each within the scatter of the next).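

In this assay, sec-butyl in place of pentyl on a saturated chain carbon bound to an oxygen on an unsaturated carbon and a triple-bonded carbon gives a 5.6-fold lower number from compound 1 to compound 3 (0.75 log units; beyond the scatter). This position therefore responds to the alkyl group it carries, which compound 2, differing from compound 1 in more than one place, could not show. Nothing measured here accounts for the step.

Sec-butyl differs from pentyl in both branching and chain length, and the compounds shown do not separate the two. A straight butyl chain at this carbon would separate them, and an isopropyl or cyclohexyl group would test how far the step extends.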